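Moving the methyl along the acid chain

A few compounds are considered here, and "the series" means these few. Any claim that something is new, unique, unknown or untested is made for them only; others in the source may bear on it.

Compound 3 `Cc1nc(-c2ccc(C(F)(F)F)cc2)sc1CNc1ccc(CC(C)C(=O)O)cc1` stands highest of three analogues in a functional assay on CHO cells for agonist activity at Free fatty acid receptor 1 (Homo sapiens), read by a luciferase reporter (on this read-out higher numbers stand for larger maximal responses and lower numbers for smaller maximal responses), where compound 3 gives 100%. Compound 1 `Cc1nc(-c2ccc(C(F)(F)F)cc2)sc1CNc1ccc(CC(=O)O)cc1` gives 18%, and compound 2 `Cc1nc(-c2ccc(C(F)(F)F)cc2)sc1CNc1ccc(CCCC(=O)O)cc1` gives 44%. The steps of a number 82 percentage points higher from compound 1 to compound 3 (beyond the scatter) and a number 56 percentage points higher from compound 2 to compound 3 (beyond the scatter) show that the shape of the acid chain sets the size of the response. Compound 4 `Cc1nc(-c2ccc(C(F)(F)F)cc2)sc1CNc1ccc(C(C)CC(=O)O)cc1` holds the same atoms as compound 3, joined differently: 1-(carboxymethyl)ethyl in place of 2-carboxypropyl on an aromatic carbon. For the measured compounds named here, no measured step matches this rearrangement, but the lengthening step a number 26 percentage points higher from compound 1 to compound 2 (beyond the scatter) and the branching step a number 56 percentage points higher from compound 2 to compound 3 (beyond the scatter) together suggest that compound 4 is expected to fall by a large step of a number 45 percentage points lower from compound 3 to compound 4 (beyond the scatter). Compound 4 is therefore estimated to give about 55%, within 25% to 90%.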

Compound 4, largest response reached (reported as percent of maximum), in percent of the reference or control that the assay uses: 109%
For compound 4 the middle estimate is 54 percentage points below the measured one, and the stated range ends below it.
By their numbers in this assay, from the lowest: compound 1; then compound 2; then compounds 3 and 4 (each within the scatter of the next).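

In this assay the methyl can move along the acid chain without a readable change, since 1-(carboxymethyl)ethyl in place of 2-carboxypropyl gives a number 9 percentage points higher from compound 3 to compound 4 (within the scatter). The new branched chain also stands well clear of the unbranched 3-carboxypropyl and the shorter carboxymethyl, with a number 65 percentage points higher from compound 2 to compound 4 (beyond the scatter) and a number 91 percentage points higher from compound 1 to compound 4 (beyond the scatter). No measurement shown here explains this tolerance. From the compounds shown here alone, whether an ethyl branch or a hydroxyl on the same chain would keep this response remains open. So does how potent compound 3 and compound 4 are, as only maximal responses are shown.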